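This account rests on a few compounds, and the source may have more. Where it says the series, first, only, none or still open, it means among the compounds named here.

Compound 1 `CCC(=O)OCCc1c(-c2ccccc2Cl)c2cc(Cl)ccc2[nH]c1=O` is the starting point. In an ADME assay on HepG2 2.2.15 cells (Homo sapiens) for cytotoxicity (a higher number here means that more compound is tolerated, a lower number that less compound is tolerated), compound 1 gives 95000 nM. Compound 2 `O=C(OCCc1c(-c2ccccc2Cl)c2cc(Cl)ccc2[nH]c1=O)c1cccnc1` carries a pyridin-3-yl where compound 1 carries an ethyl on the carbonyl carbon, and in this assay compound 2 gives 170000 nM. The step of a 1.8-fold higher number from compound 1 to compound 2 (0.25 log units; within the scatter) shows that these two numbers sit within the scatter of each other, so compound 2 stands alongside compound 1 rather than apart from it.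

Compound 3 `COc1ccc(/C=C/C(=O)OCCc2c(-c3ccccc3Cl)c3cc(Cl)ccc3[nH]c2=O)cc1OC` is not yet measured. It differs from compound 2 in one place: 2-(3,4-dimethoxyphenyl)ethenyl in place of pyridin-3-yl on a carbonyl carbon. For the measured compounds named here, the only step that bears on this is the change at the same carbonyl carbon, a 1.8-fold higher number from compound 1 to compound 2 (0.25 log units; within the scatter), which did not move the number beyond the scatter. On that basis no step beyond the scatter is expected, and the estimated step is a 1.1-fold lower number from compound 2 to compound 3 (0.05 log units; within the scatter). For compound 3 the expected value in this assay is 150000 nM, within a range of 60000 nM to 350000 nM.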

Compound 3, half-maximal cytotoxic concentration: > 1200000 nM
Compound 3: a limit, no number (the forecaster's own chance of this, stated with the estimate: 25%); middle value at least 8.0-fold (0.90 log units) from the limit.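

In this assay, the group on this carbonyl carbon can matter after all: 2-(3,4-dimethoxyphenyl)ethenyl in place of pyridin-3-yl gives an at least 7.0-fold higher number from compound 2 to compound 3 (0.84 log units; beyond the scatter), and in place of ethyl it gives an at least 12-fold higher number from compound 1 to compound 3 (1.10 log units; beyond the scatter). Of the three groups shown, it is the only one that moves the number beyond the scatter, whereas ethyl and pyridin-3-yl remain within the scatter of each other. The reading for compound 3 is a limit and not a number, so the full size of both steps remains unknown: the limit of > 1200000 nM in this assay, at which 1 of the 3 values shown sits.

The new group brings a carbon-only aromatic ring, a double bond and methoxy groups all at once, and the compounds shown cannot tell which of these goes with the step. Going by these compounds, a plain phenyl group, or the same dimethoxyphenyl ring on a saturated chain, could separate them, and how an amine would read on this carbon also remains open.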